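A few compounds are considered here, and "the series" means these few. Any claim that something is new, unique, unknown or untested is made for them only; others in the source may bear on it.

Going by the values given here, compound 1 `COc1ccc(C2Nc3ccccc3C(=O)N2Cc2ccccc2)cc1COc1cccc(NC(C)=O)c1` is the only compound here with a number: in a functional assay on HEK-EM293 cells for agonist activity at Thyrotropin receptor (Homo sapiens), read by ELISA and cAMP accumulation, with a stated time of 1 h (on this read-out higher numbers stand for an effect only at larger amounts of compound and lower numbers for an effect already at smaller amounts), compound 1 gives 4340 nM. Compound 2 `COc1ccc(C2Nc3ccccc3C(=O)N2Cc2ccccc2)cc1COc1ccc(C#N)cc1` was tested in this assay, but for compound 2 the entry reads "not determined" (no result reported), so it has no standing on the numbers shown. Compound 3 `COc1ccc(C2Nc3ccccc3C(=O)N2Cc2ccccc2)cc1CSc1ccc(NC(C)=O)cc1` differs from compound 2 in one place: (4-acetamidophenyl)sulfanyl in place of 4-cyanophenoxy on a saturated chain carbon bound to an aromatic carbon. Among the compounds with values here, without a value for compound 2, no step in this assay can be sized, and nothing beyond the usual scatter is assumed. Resting on compound 1 alone, compound 3 is estimated at 4000 nM, within 1000 nM to 15000 nM.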

Compound 3, half-maximal effective concentration: 80 nM
Estimate against measurement, compound 3: 50-fold (1.70 log units) above, and the stated range ends above it.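

In this assay the change gives a 54-fold lower number from compound 1 to compound 3 (1.73 log units; beyond the scatter), so the group on this saturated chain carbon bound to an aromatic carbon has a large effect on the read-out. The two groups differ in both the linking atom, sulfur against oxygen, and in the name's number for the acetamido group, so this single step cannot be divided between those two differences. Nothing available explains the size of the step.

The step from compound 2 to compound 3 cannot be read. Also open, on these data alone, is how an amine or a carboxylic acid would compare with the acetamido group of compound 3.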